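The source may hold more compounds than are shown below. What is called first, only, known or untested is meant among the compounds shown, and "the series" means these compounds.

Measured in a physicochemical assay for solubility, with a stated time of 18 h, at pH 7.4; on this read-out higher numbers stand for higher solubility and lower numbers for lower solubility:

compound 1 `c1ccc(CCc2ccc3c(NCCCNCc4ccco4)ccnc3c2)cc1` gives 4200 nM
compound 2 `COc1ccccc1Oc1ccc2c(NCCCNCc3ccco3)ccnc2c1` gives 14500 nM
compound 3 `COc1ccc(F)cc1CNCCCNc1ccnc2cc(Oc3ccccc3OC)ccc12` gives 14500 nM

Compound 4 `COc1ccc(F)cc1CNCCCNc1ccnc2cc(CCc3ccccc3)ccc12` is not yet measured in this assay. It differs from compound 3 by phenethyl in place of 2-methoxyphenoxy on an aromatic carbon. The same change is already measured once, from compound 2 to compound 1, where it reads phenethyl in place of 2-methoxyphenoxy on an aromatic carbon and gave a 3.5-fold lower number from compound 2 to compound 1 (0.54 log units; beyond the scatter). The two place lines agree word for word, so the change is the same, made on a different core: compound 3 differs from compound 2 by 5-fluoro-2-methoxyphenyl in place of furan-2-yl on a saturated chain carbon bound to an amine nitrogen, a change that itself gave no change at the digits printed from compound 2 to compound 3 (within the scatter).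

From compound 3 to compound 4 a step of about a 3.5-fold lower number from compound 3 to compound 4 (0.54 log units; beyond the scatter) is expected, resting on the step of a 3.5-fold lower number from compound 2 to compound 1 (0.54 log units; beyond the scatter) seen for the same change; the core difference left the number unchanged, so no reason is seen here to expect otherwise. Compound 4 is thus estimated at 4200 nM, with a range from 1500 nM to 11000 nM.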

Compound 4, solubility: 4200 nM
Estimate against measurement, compound 4: no gap at the digits printed; low and high end bracket the measured number.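

In this assay phenethyl in place of 2-methoxyphenoxy on an aromatic carbon gives a 3.5-fold lower number from compound 3 to compound 4 (0.54 log units; beyond the scatter) and, on the other core, a 3.5-fold lower number from compound 2 to compound 1 (0.54 log units; beyond the scatter) so the step carries over at the same size, while 5-fluoro-2-methoxyphenyl in place of furan-2-yl gives no change at the digits printed from compound 1 to compound 4 (within the scatter) with phenethyl present as well. For the compounds shown here, this rests on only two cores that differ in one place, and it does not show that the step would hold on cores further removed. Nothing measured here gives a reason for the step.

The compounds shown leave open whether a carboxylic acid, a morpholine or a longer chain on that aromatic carbon would follow the same pattern. They also leave open whether the step holds with a pyridine ring in place of furan-2-yl on the saturated chain carbon bound to an amine nitrogen.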